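The source may hold more compounds than are shown below. What is called first, only, known or untested is meant among the compounds shown, and "the series" means these compounds.

Measured compounds:
compound 1, `CCN(CC)c1ccc(/C=C2/SC(Nc3ccccc3)=NC2=O)cc1`, with > 100000 nM in an ADME assay on cells (Homo sapiens) for cytotoxicity, read by sulforhodamine B assay, with a stated time of 48 h; a lower number here means that less compound is needed, a higher number that more compound is needed for the effect
compound 2, `CN1CCN(c2ccc(/C=C3/SC(Nc4ccccc4)=NC3=O)cc2)CC1`, with 6400 nM in this assay

Compound 1 gives only a limit of the assay in this assay, > 100000 nM. For the measured compounds named here, compound 2 therefore holds the only real number in this assay; the other entry is a limit (the limit of > 100000 nM in this assay, at which 1 of the 2 values shown sits). Going by the values given here, the one measured step, an at least 15-fold lower number from compound 1 to compound 2 (1.19 log units; beyond the scatter), is large and lies beyond the scatter.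

Compound 3, `O=C1N=C(Nc2ccccc2)S/C1=C/c1ccc(N2CCNCC2)cc1`, differs from compound 2 by hydrogen in place of methyl on an amine nitrogen in a ring. Among the compounds with values here, no measured step touches the methyl on that ring nitrogen, so the step from compound 1 to compound 2, which exchanges the whole amine, gives no direct guide to this smaller change. Without a comparable step in hand, compound 3 is expected to stay close to compound 2 in this assay, with a 1.3-fold higher number from compound 2 to compound 3 (0.10 log units; within the scatter). The estimate for compound 3 in this assay is therefore 8000 nM, with a range from 2000 nM to 40000 nM.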

Compound 3, half-maximal effective concentration: > 100000 nM
Compound 3 gave a limit, no number; the forecaster's own chance of this, stated with the estimate: 15%; middle value at least 12-fold (1.09 log units) from the limit.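

In this assay, the change from 4-methylpiperazin-1-yl to piperazin-1-yl, with only a methyl on an amine nitrogen in a ring giving way to hydrogen, gives an at least 15-fold higher number from compound 2 to compound 3 (1.19 log units; beyond the scatter). The earlier step exchanged the whole amine, whereas this one shows that the six-membered ring alone does not bring the measurable number, and that the methyl on its nitrogen goes with it among these compounds. Compound 2 thus stays the only compound with a real number, and the other two entries are limits: the limit of > 100000 nM in this assay, at which 2 of the 3 values shown sit.

As far as these compounds go, the step between compound 1 and compound 3 cannot be read, since both values are limits, and how far either compound lies past its limit stays open. Also open, from the compounds shown here alone, is whether an ethyl or an acetyl group on the same ring nitrogen would keep a measurable number like that of compound 2.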